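The source may report more compounds than this note shows. Statements on the series, on what has been measured and on what is new or still open speak of the compounds shown alone.

Measured compounds:
- compound 1 `CCCCCCCN(CCOCCSc1nc(-c2ccc(OC)cc2)c(-c2ccc(OC)cc2)[nH]1)C(=O)NC(C)C` gives 850 nM in an assay on microsomes from liver with sterol O-acyltransferase 1 (Rattus norvegicus) as the target; on this read-out higher numbers stand for weaker inhibition and lower numbers for stronger inhibition
- compound 2 `CCOCCOCCN(CCCCCSc1nc(-c2ccccc2)c(-c2ccccc2)[nH]1)C(=O)NC(C)C` gives 30 nM in this assay

Of these two numbers, compound 2 has the lower one; compound 1 sits at a value that is beyond the usual scatter, so compound 2 is the stronger inhibitor of the pair. The two structures differ in several places at once, so nothing more than that comparison can be drawn from them.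

Compound 3 `CCCCOCCN(CCCCCSc1nc(-c2ccccc2)c(-c2ccccc2)[nH]1)C(=O)NC(C)C` is the next compound. It keeps the core of compound 2 and changes only one end of a side chain: ethyl in place of ethoxy on a saturated chain carbon, two bonds along the chain from an oxygen on a saturated carbon. Among the compounds with values here, this is a small trim of the chain, and no measured pair shows what such a trim does here. The expectation is therefore a step in this assay of no clear direction and within the scatter, written as a 1.3-fold higher number from compound 2 to compound 3 (0.12 log units; within the scatter). Compound 3 is expected to come out near 40 nM, with a range from 12 nM to 130 nM.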

Compound 3, half-maximal inhibitory concentration: 190 nM
Estimate against measurement, compound 3: 4.8-fold (0.68 log units) below; measured number outside the range, above it.
By their numbers in this assay, from the lowest: compound 2; then compound 3; then compound 1.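

Within the data shown here, this is the first pair here that differs in only one place, so the end of this side chain can now be judged on its own in this assay: putting ethyl in place of ethoxy gives a 6.3-fold higher number from compound 2 to compound 3 (0.80 log units; beyond the scatter). The change is small, yet the higher number means weaker inhibition, so this end of the chain is not free to be trimmed without consequence. Nothing available here explains the step.

The compounds shown leave open whether the loss of the oxygen or the shorter end accounts for this step, as both change together in this single pair. They also leave open how this assay would read for a methoxy group, a longer chain or an amine at this same place.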